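A few compounds are considered here, and "the series" means these few. Any claim that something is new, unique, unknown or untested is made for them only; others in the source may bear on it.

Compound 1 `Cc1cc(OCc2nc3ccccc3s2)ccc1NC(=O)Nc1ccccc1Cl`: 830 nM
Compound 2 `O=C(Nc1ccccc1)Nc1ccc(OCc2nc3ccccc3s2)cc1`: 420 nM

In an assay on isolated protein for inhibition of Polyunsaturated fatty acid 5-lipoxygenase (Homo sapiens), read by HPLC, with a stated time of 10 min (on this read-out lower numbers stand for stronger inhibition and higher numbers for weaker inhibition), compound 2 gives 420 nM, the lower of the two numbers recorded, while compound 1 gives 830 nM; the two lie within the scatter of each other, so no order between them is claimed. Compound 3 `O=C(Nc1ccc(OCc2nc3ccccc3s2)cc1)Nc1ccccc1Cl` differs from compound 2 by chloro in place of hydrogen on an aromatic carbon. Among the compounds with values here, no measured pair differs in one place alone, so the size of this step cannot be read from the series; compound 1, which also bears a chloro, sits within the scatter of compound 2. In this assay the step of a 1.2-fold higher number from compound 2 to compound 3 (0.08 log units; within the scatter) is therefore expected to stay within the scatter. Compound 3 is expected to give 500 nM, with a range from 200 nM to 1300 nM.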

Compound 3, half-maximal inhibitory concentration: 360 nM
Estimate against measurement, compound 3: 1.4-fold (0.14 log units) above; the measured number falls inside the stated range.
By their numbers in this assay, from the lowest: compounds 3, 2 and 1 (each within the scatter of the next, the first and the last beyond it).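

Phenyl to 2-chlorophenyl, ortho to a large group, stays within the scatter in this assay (a 1.2-fold lower number from compound 2 to compound 3 (0.07 log units; within the scatter)). Hydrogen in place of methyl on an aromatic carbon gives the first step in the series beyond the scatter, though a modest one (a 2.3-fold lower number from compound 1 to compound 3 (0.36 log units; beyond the scatter)). Nothing available explains either step.

On these data alone, whether fluoro, methoxy or a carboxylic acid at the chloro position would also stay within the scatter remains open. Also open, as far as these compounds go, is whether the methyl step keeps its size without the chloro.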